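Adding a Propargylsulfanyl Group to a Weak Inhibitor

The compounds below may be only part of what the source reports. "The series", "measured", "known", "first", "only" and "open" are said of these compounds alone.

Compound 1 `Cc1cc(Nc2cc(-c3ccccc3)[nH]n2)n2ncnc2n1` is the starting point. In an ADME assay on GES1 cells (Homo sapiens) for inhibition, read by MTT assay, with a stated time of 72 h (a lower number here means a stronger inhibitor, a higher number a weaker inhibitor), compound 1 gives > 50000 nM, and this is a limit of the assay rather than a measured number. Two related compounds do give numbers: compound 2 `Cc1cc(Nc2ccn(Cc3nc(C)c4ccccc4n3)n2)n2nc(SCc3ccc(Br)cc3)nc2n1` gives 36800 nM in this assay, and compound 3 `Cc1cc(Nc2cc(-c3cccs3)[nH]n2)n2nc(SCc3ccc(Br)cc3)nc2n1` gives 38700 nM. All three compounds therefore sit at the weak end of what this assay can report, where the limit of > 50000 nM in this assay, at which 1 of the 3 values shown sits, marks the edge of measurement.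

Compound 4 `C#CCSc1nc2nc(C)cc(Nc3cc(-c4ccccc4)[nH]n3)n2n1` differs from compound 1 by a single change: propargylsulfanyl in place of hydrogen on an aromatic carbon. No pair of measured compounds that differ in only one place is available, so the size of such a step cannot be read from the data shown. The expectation is that the step from compound 1 to compound 4, an at least 1.1-fold lower number from compound 1 to compound 4 (0.04 log units; that floor lies within the scatter), stays within the usual scatter, with compound 4 remaining a weak inhibitor. Compound 4 is expected to give about 45000 nM, within a range from 20000 nM to 100000 nM, and a limit rather than a number remains a real possibility.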

Compound 4, half-maximal inhibitory concentration: 45700 nM
Compound 4: middle estimate off by 1.0-fold (0.01 log units), on the low side; the range from low to high includes it.
By their numbers in this assay, from the lowest: compounds 2, 3 and 4 (each within the scatter of the next). At a limit, above all of these: compound 1.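

Within the data shown here, at this aromatic carbon, between two ring nitrogen atoms, propargylsulfanyl in place of hydrogen gives the first step that can be read at this position, an at least 1.0-fold lower number from compound 1 to compound 4 (0.03 log units; that floor lies within the scatter) in this assay. The change replaces a limit with a measured number, but that number still lies at the weak end of what the assay reports, so propargylsulfanyl here brings no strong inhibition. The step is only a floor, because compound 1 sits at the edge of measurement: the limit of > 50000 nM in this assay, at which 1 of the 4 values shown sits.

As far as these compounds go, how far the true step reaches past that floor stays open, as compound 1 has no exact number. Also open, from the compounds shown here alone, is how a different group on this same carbon, such as an amine or a longer chain ending in a carboxylic acid, would compare with propargylsulfanyl.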